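Moving the Triple Bond Within a Sugar-Like Ring

The source may hold more compounds than are shown below. What is called first, only, known or untested is meant among the compounds shown, and "the series" means these compounds.

Three nucleoside-like compounds have been tested in a functional assay on L1210 cells (Mus musculus), read by MTT assay; on this read-out higher numbers stand for weaker inhibition and lower numbers for stronger inhibition. Compound 1 `C#CC[C@]1(O)[C@@H](CO)O[C@@H](n2ccc(=O)[nH]c2=O)[C@@H]1O` reaches only a limit of the assay, > 350000 nM. Compound 2 `C#CC[C@]1(O)[C@@H](CO)OC(n2ccc(N)nc2=O)[C@@H]1O` likewise stops at the limit > 350000 nM. Compound 3 `C#CC[C@@]1(O)[C@@H](CO)O[C@@H](n2ccc(=O)[nH]c2=O)[C@@H]1O` also gives just the limit > 350000 nM. The step from compound 1 to compound 3 is a step that the two limits leave unreadable from compound 1 to compound 3; its size cannot be read because the limit of > 350000 nM in this assay, at which 3 of the 3 values shown sit, hides it, even though the fact that compounds 1 and 3 differ only in the configuration as drawn is all that separates them.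

Compound 4 `CC#C[C@@]1(O)[C@@H](CO)O[C@@H](n2ccc(=O)[nH]c2=O)[C@@H]1O` differs from compound 3 by prop-1-yn-1-yl in place of propargyl on a saturated ring carbon. Among the measured compounds shown here, no measured step gives a readable size for such a change, so nothing beyond the scatter can be anticipated. The step from compound 3 to compound 4 is expected to be a number no higher from compound 3 to compound 4 (the limit leaves the size open). Compound 4 is therefore estimated at 350000 nM, within 100000 nM to 1000000 nM.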

Compound 4, half-maximal inhibitory concentration: 354000 nM
For compound 4 the middle estimate is 1.0-fold (0.00 log units) below the measured one; the range from low to high includes it.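

No size can be read for the step between compound 3 and compound 4, as the value for compound 3 is only a limit of the assay. The compounds shown leave open how much moving the triple bond changes inhibition.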